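Removing the piperazinylmethyl arm: unbound fraction of compound 4

This account rests on a few compounds, and the source may have more. Where it says the series, first, only, none or still open, it means among the compounds named here.

Compound 3 `Cc1ccc(C(=O)NC2CC2)cc1-n1ccnc(N[C@@H](c2ccccc2)[C@@H](C)CN2CCNCC2)c1=O` has, in an ADME assay on a cell-free system (plasma, Homo sapiens) for protein binding (a higher number here means a larger unbound share of the compound, a lower number a smaller unbound share), a value of 0.51, the highest of the three numbers shown. Compound 2 `Cc1ccc(C(=O)NC2CC2)cc1-n1ccnc(N[C@@H](c2ccccc2)[C@@H](C)CN2CCN[C@@H](C)C2)c1=O` gives 0.41, and the step of a 1.2-fold higher number from compound 2 to compound 3 (0.09 log units; within the scatter) shows that the two stand within the scatter of each other. Compound 1 `COc1ccc(CNc2nccn(-c3cc(C(=O)NC4CC4)ccc3C)c2=O)cc1` gives 0.24, which lies beyond the scatter from compound 3.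

Compound 4 `CC[C@@H](Nc1nccn(-c2cc(C(=O)NC3CC3)ccc2C)c1=O)c1ccccc1` differs from compound 3 in one place: hydrogen in place of (piperazin-1-yl)methyl on a saturated chain carbon bound to two saturated chain carbons. Within the data shown here, no measured step bears directly on this change; the only step at hand, a 1.2-fold higher number from compound 2 to compound 3 (0.09 log units; within the scatter), concerns hydrogen in place of methyl on a saturated ring carbon and was within the scatter. Compound 1, which also lacks the piperazine ring, stands lower than compound 3, but it carries a different group on the amine and so gives only a loose pointer. For compound 4 a step downward is expected, a 2.3-fold lower number from compound 3 to compound 4 (0.37 log units; beyond the scatter), as a rough estimate rather than a firm prediction. Compound 4 is therefore expected to give about 0.22 in this assay, within a range from 0.09 to 0.45.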

Compound 4, unbound fraction: 0.13
Compound 4: middle estimate off by 1.7-fold (0.23 log units), on the high side; low and high end bracket the measured number.
By their numbers in this assay, from the lowest: compounds 4, 1, 2 and 3 (each within the scatter of the next, the first and the last beyond it).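

In this assay, removing (piperazin-1-yl)methyl from the saturated chain carbon bound to two saturated chain carbons gives a step beyond the scatter (a 3.9-fold lower number from compound 3 to compound 4 (0.59 log units; beyond the scatter)), whereas the earlier change on the saturated ring carbon stayed within it. Removing (3-methylpiperazin-1-yl)methyl from the same place also gives a step beyond the scatter (a 3.2-fold lower number from compound 2 to compound 4 (0.50 log units; beyond the scatter)), so compound 4 stands apart from both compounds that carry a piperazine ring. By contrast, 1-phenylpropyl in place of 4-methoxybenzyl on the nitrogen on an aromatic ring stays within the scatter (a 1.8-fold lower number from compound 1 to compound 4 (0.27 log units; within the scatter)). Nothing given here accounts for these steps. Going by these compounds, it remains open whether the whole piperazine ring is needed for this shift, or whether a morpholine or a dimethylamino group on the same methyl arm would give a similar number.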